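The source may hold more compounds than are shown below. What is called first, only, known or untested is meant among the compounds shown, and "the series" means these compounds.

Three amides sharing one core were tested in a functional assay on BSY-1 cells (Homo sapiens) for inhibition, read by colorimetric assay and sulforhodamine B assay, with a stated time of 48 h; a higher number here means a weaker inhibitor of growth, a lower number a stronger inhibitor of growth. Compound 1 (`CCCCCCCCCCCC[C@@H](O)[C@H]1CC[C@H]([C@H](O)CCCCCCCCCCNC(=O)c2ccco2)O1`) gives 490 nM, compound 2 (`CCCCCCCCCCCC[C@@H](O)[C@H]1CC[C@H]([C@H](O)CCCCCCCCCCNC(=O)c2ccoc2)O1`) gives 2190 nM, and compound 3 (`CCCCCCCCCCCC[C@@H](O)[C@H]1CC[C@H]([C@H](O)CCCCCCCCCCNC(=O)c2cncs2)O1`) gives 3980 nM. Compound 3 cannot be separated from compound 2, with a 1.8-fold higher number from compound 2 to compound 3 (0.26 log units; within the scatter), but it stands clearly apart from the furan-2-yl amide, with an 8.1-fold higher number from compound 1 to compound 3 (0.91 log units; beyond the scatter).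

The next analogue, compound 4 (`CCCCCCCCCCCC[C@@H](O)[C@H]1CC[C@H]([C@H](O)CCCCCCCCCCNC(=O)c2ccsc2)O1`), carries thiophen-3-yl in place of 1,3-thiazol-5-yl on a carbonyl carbon. Among the compounds with values here, no measured step makes this exact exchange. The nearest guide is the furan-3-yl amide, compound 2, at 2190 nM, although a 4.5-fold higher number from compound 1 to compound 2 (0.65 log units; beyond the scatter) shows that exchanging one ring for another can carry the number beyond the scatter. In this assay, little or no step beyond the scatter is therefore expected, and any shift should be toward a lower number. The expected change is a 1.8-fold lower number from compound 3 to compound 4 (0.26 log units; within the scatter). For compound 4 the estimated value is 2200 nM, with an expected range of 700 nM to 5500 nM.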

Compound 4, concentration for 50% growth inhibition: 3020 nM
Beside the measured number, compound 4's estimate is 1.4-fold (0.14 log units) below it; the range from low to high includes it.
By their numbers in this assay, from the lowest: compound 1; then compounds 2, 4 and 3 (each within the scatter of the next).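

In this assay, replacing 1,3-thiazol-5-yl with thiophen-3-yl on the carbonyl carbon removes the ring nitrogen without a step beyond the scatter, giving a 1.3-fold lower number from compound 3 to compound 4 (0.12 log units; within the scatter), and the exchange of furan-3-yl for thiophen-3-yl also stays within it, giving a 1.4-fold higher number from compound 2 to compound 4 (0.14 log units; within the scatter). Compound 2, compound 3 and compound 4 therefore form a group that these numbers cannot separate, while compound 1 stands apart from all of them, including a 6.2-fold higher number from compound 1 to compound 4 (0.79 log units; beyond the scatter). Nothing measured here explains why the furan-2-yl amide differs from the others.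

The compounds shown leave open whether a thiophen-2-yl amide would match compound 1 or fall with compound 4. They also leave open how a phenyl ring or a simple acetyl group would read at this position.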